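Same Fluoro Step, Second Core, Cell Viability

The source may hold more compounds than are shown below. What is called first, only, known or untested is meant among the compounds shown, and "the series" means these compounds.

Measured compounds in an ADME assay on BV-2 cells (Mus musculus) for cytotoxicity, with a stated time of 24 h, tested at 50 uM; on this read-out higher numbers stand for a weaker effect at the one concentration tested and lower numbers for a stronger effect:
compound 1 `COc1ccccc1S(=O)(=O)/C=C/c1ccccn1` gives 100%
compound 2 `COc1ccccc1S(=O)(=O)/C=C/c1ncccc1F` gives 99.2%
compound 3 `COc1cccc(S(=O)(=O)/C=C/c2ccccn2)c1` gives 98.9%

Compound 1 and compound 2 differ by one change, (fluoro in place of hydrogen on an aromatic carbon), and in this assay that change made a step of a number 0.8 percentage points lower from compound 1 to compound 2 (within the scatter). Compound 3 shares the atoms of compound 1 but joins them differently; the difference between the two cores is not broken down here. In this assay the values of compound 1 and compound 3 lie within the scatter of each other, as do those of compound 2 and compound 3.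

Compound 4 `COc1cccc(S(=O)(=O)/C=C/c2ncccc2F)c1` has not been measured. It stands to compound 3 as compound 2 stands to compound 1: the change is fluoro in place of hydrogen on an aromatic carbon, and its place matches that of the earlier change word for word, so it is the same change on the other core.

Because the earlier step was a number 0.8 percentage points lower from compound 1 to compound 2 (within the scatter), and because compound 3 sits at 98.9%, a step of a number 0.4 percentage points lower from compound 3 to compound 4 (within the scatter) is expected. Compound 4 is estimated at 98.5%, between 92% and 100%.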

Compound 4, a percentage reported as activity, at one concentration (the size of the read-out at that concentration, not a potency): 97.4%
Compound 4: the middle estimate sits 1.1 percentage points above what was measured, and the stated range covers the measured number.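

In this assay the fluoro change on the second core gave a number 1.5 percentage points lower from compound 3 to compound 4 (within the scatter), and set beside the step on the first core the two agree: the same change on two cores in this assay, a number 0.8 percentage points lower (within the scatter) from compound 1 to compound 2 and a number 1.5 percentage points lower (within the scatter) from compound 3 to compound 4, 0.7 percentage points apart, within the scatter of two such steps. Within these four compounds, then, the change carries from one core to the other with no visible difference, and on neither core does it move the number beyond the usual scatter. Among the compounds shown here, this does not show that the change would behave alike on other cores or in other assays: all four values come from a single concentration and a single time, and only two pairs of compounds are available.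

The compounds shown leave open whether another group in the same place, such as a trifluoromethyl, an amine or a carboxylic acid, would also stay within the scatter of the parent compounds in this assay. They also leave open whether fluoro elsewhere on the ring with the nitrogen would give a step of similar size.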